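Closing a Branched Chain into a Ring on the Amine Side

A few compounds are considered here, and "the series" means these few. Any claim that something is new, unique, unknown or untested is made for them only; others in the source may bear on it.

Two compounds share a core and differ in the side chain that carries an amine. Compound 1 `CC[C@H](C)[C@H](N)CN(C(=O)[C@@H]1C[C@H]1c1ccccc1)c1ccc(-c2ccccc2)cc1` has a short branched chain with a free amine. In a functional assay for agonist activity at G protein-coupled receptor 88 (Homo sapiens), read by HTRF and cAMP accumulation (a higher number here means that more compound is needed for the effect, a lower number that less compound is needed), compound 1 gives 230 nM; 800 nM (2 entries), as recorded in the several entries of compound 1 in this assay, 230 nM; 800 nM (2 entries). Compound 2 `CCC(C)CNCCN(C(=O)[C@@H]1C[C@H]1c1ccccc1)c1ccc(-c2ccccc2)cc1` has a longer chain ending in an amine that bears a 2-methylbutyl group. In this assay compound 2 gives 4.7 nM, the only number shown for it; a further entry for compound 2 reports no single number. Compound 3 `O=C([C@@H]1C[C@H]1c1ccccc1)N(CCNCC1CCCC1)c1ccc(-c2ccccc2)cc1` has not yet been measured. It differs from compound 2 in one place: cyclopentyl in place of sec-butyl on a saturated chain carbon bound to an amine nitrogen. For the measured compounds named here, an open branched chain is exchanged for a closed ring, and since no pair of measured compounds differs in just one place, the expectation rests on this change alone. For compound 3 the step expected in this assay is a 1.7-fold higher number from compound 2 to compound 3 (0.23 log units; within the scatter), a shift not beyond the usual scatter of the measurement. Compound 3 is therefore expected to give 8 nM, with a likely range from 2 nM to 40 nM.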

Compound 3, half-maximal effective concentration: 2.5 nM
Compound 3: middle estimate off by 3.2-fold (0.51 log units), on the high side; measured number inside the range.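

For the compounds shown here, until now the group on this amine had been seen only in its open, branched form, so nothing showed whether it could be closed into a ring. In this assay, exchanging sec-butyl for cyclopentyl gives a 1.9-fold lower number from compound 2 to compound 3 (0.27 log units; within the scatter), so the two compounds cannot be told apart, and the closed ring, with one more carbon, serves at this place as well as the open branch does. So small a step should not be read as a gain, since entries for a single compound can lie well apart, as they do here: the several entries of compound 1 in this assay, 230 nM; 800 nM (2 entries).

As far as these compounds go, whether this place accepts more than these two groups of carbon only stays open: a cyclohexyl ring, a phenyl ring or a tetrahydropyranyl ring, which brings in an oxygen atom, could each give a different answer. A single pair also cannot say whether the same exchange would hold if the rest of the molecule were changed.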